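Swapping a Difluorophenyl Amide for a Propylphenyl Amide

The source may hold more compounds than are shown below. What is called first, only, known or untested is meant among the compounds shown, and "the series" means these compounds.

Three amides built on one shared core have been tested in a functional assay on HCC1937 cells (Homo sapiens) for antiproliferative activity, read by CCK-8 assay, with a stated time of 72 h; a higher number here means a weaker inhibitor, a lower number a stronger inhibitor. Compound 1 `CCc1ccc(C(=O)Nc2cccc(-c3oc4cc(-c5ccc(F)cc5)ccc4c(=O)c3O)c2)cc1` gives 13200 nM, compound 2 `O=C(Nc1cccc(-c2oc3cc(-c4ccc(F)cc4)ccc3c(=O)c2O)c1)c1ccc(Cl)nc1` gives 7550 nM, and compound 3 `O=C(Nc1cccc(-c2oc3cc(-c4ccc(F)cc4)ccc3c(=O)c2O)c1)c1cc(F)cc(F)c1` gives 2070 nM, making compound 3 the strongest inhibitor of the three, since a 6.4-fold lower number from compound 1 to compound 3 (0.80 log units; beyond the scatter) and a 3.6-fold lower number from compound 2 to compound 3 (0.56 log units; beyond the scatter) both lie beyond the scatter. Compound 4 `CCCc1ccc(C(=O)Nc2cccc(-c3oc4cc(-c5ccc(F)cc5)ccc4c(=O)c3O)c2)cc1` differs from compound 3 in one place: 4-propylphenyl in place of 3,5-difluorophenyl on a carbonyl carbon. The step that bears most on this change is the one where a 6.4-fold lower number from compound 1 to compound 3 (0.80 log units; beyond the scatter), taken in reverse, as 4-propylphenyl is close to 4-ethylphenyl. With compound 1 giving 13200 nM as the guide, the expected step for compound 4 is a 5.8-fold higher number from compound 3 to compound 4 (0.76 log units; beyond the scatter). Compound 4 is therefore estimated at 12000 nM, within a range of 4000 nM to 36000 nM.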

Compound 4, half-maximal inhibitory concentration: 15400 nM
Compound 4: middle estimate off by 1.3-fold (0.11 log units), on the low side, within the range that was stated.
By their numbers in this assay, from the lowest: compound 3; then compounds 2, 1 and 4 (each within the scatter of the next, the first and the last beyond it).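

In this assay, extending 4-ethylphenyl to 4-propylphenyl on this carbonyl carbon gives a 1.2-fold higher number from compound 1 to compound 4 (0.07 log units; within the scatter), so the added methyl makes no measurable difference here. The longer chain also stays well behind 3,5-difluorophenyl, with a 7.4-fold higher number from compound 3 to compound 4 (0.87 log units; beyond the scatter), and just behind 6-chloropyridin-3-yl, with a 2.0-fold higher number from compound 2 to compound 4 (0.31 log units; beyond the scatter). Nothing measured here gives a reason for these differences. Still open, from the compounds shown here alone, is whether a longer chain, such as 4-butylphenyl, would also match compound 1. Also open, going by these compounds, is whether an amine or a carboxylic acid on this phenyl ring would approach compound 3.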